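A few compounds are considered here, and "the series" means these few. Any claim that something is new, unique, unknown or untested is made for them only; others in the source may bear on it.

Values measured in a functional assay on HCT-116 cells (Homo sapiens) for antiproliferative activity, read by resazurin assay, with a stated time of 5 days (on this read-out lower numbers stand for stronger inhibition and higher numbers for weaker inhibition), are as follows
- compound 1 `O=C(NO)c1cc2ccc(CN3CCc4ccccc4C3)c(F)c2s1` gives 3000 nM
- compound 2 `Cc1ccc(C(=O)NCc2ccc3cc(C(=O)NO)sc3c2F)s1` gives 120 nM

Of these two numbers, compound 2 (120 nM) holds the lower, and its gap to compound 1 lies beyond the scatter. Compound 3 `COCc1ccc(C(=O)NCc2ccc3cc(C(=O)NO)sc3c2F)o1` keeps the shared core of compound 2 and differs in one place (5-(methoxymethyl)furan-2-yl in place of 5-methylthiophen-2-yl on a carbonyl carbon), counted as 5-(methoxymethyl)furan-2-yl in place of 5-methylthiophen-2-yl on a carbonyl carbon in full. Within the data shown here, no measured pair shows this change, so the expectation rests on compound 2 (120 nM) alone. In this assay the expected change is none beyond the scatter, and the estimated step is a 1.3-fold higher number from compound 2 to compound 3 (0.10 log units; within the scatter) as a working figure. The estimate for compound 3 is 150 nM with an expected range from 50 nM to 450 nM for the coming measurement.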

Compound 3, half-maximal inhibitory concentration: 310 nM
Compound 3: middle estimate off by 2.1-fold (0.32 log units), on the low side; the range from low to high includes it.
By their numbers in this assay, from the lowest: compound 2; then compound 3; then compound 1.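

Among these compounds, the carbonyl carbon bearing the amide-type nitrogen is the first place with a direct one-place comparison, and in this assay it does not treat this ring exchange as neutral: the step is a 2.6-fold higher number from compound 2 to compound 3 (0.41 log units; beyond the scatter). The change is modest, and 5-(methoxymethyl)furan-2-yl is tolerated with only this limited loss relative to 5-methylthiophen-2-yl. The exchange alters the ring hetero atom, from sulfur to oxygen, and the chain on the ring, from methyl to methoxymethyl, at once, and no available measurement explains the step.

The compounds shown leave open how much of the step belongs to the ring and how much to the chain, which a furan ring carrying a methyl or a thiophene ring carrying a methoxymethyl would separate. Also open, on these data alone, is how this position responds to a ring of another kind, such as a phenyl or a pyridine.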